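This account rests on a few compounds, and the source may have more. Where it says the series, first, only, none or still open, it means among the compounds named here.

Measured so far:
compound 1, `CN(C)CCCOc1ccc(CN(C)c2nc3ccc(Oc4ccc(C(F)(F)F)cc4)cc3s2)cc1` — 54000 nM
compound 2, `CN(Cc1ccc(OCCCN)cc1)c1nc2ccc(Oc3ccccc3)cc2s1` — 95000 nM
compound 3, `NCCCOc1ccc(CNc2nc3ccc(Oc4ccc(C(F)(F)F)cc4)cc3s2)cc1` — 112000 nM

In an assay on cells for inhibition of Voltage-dependent T-type calcium channel subunit alpha-1H (Homo sapiens), read by FLIPR and calcium flux, with stated times of 600 s and 300 s (a lower number here means a stronger inhibitor, a higher number a weaker inhibitor), compound 3 gives the highest of the three numbers. Its nearest neighbour is compound 2, whose value lies within the scatter of it; compound 1 sits furthest away, beyond the scatter. Compound 4, `CN(Cc1ccc(OCCCN)cc1)c1nc2ccc(Oc3ccc(C(F)(F)F)cc3)cc2s1`, is compound 3 with methyl in place of hydrogen on a nitrogen on an aromatic ring. Going by the values given here, no pair among the measured compounds differs in that one place alone, so the size of this step has not been seen directly. The two compounds that carry the methyl, compound 1 and compound 2, both give lower numbers than compound 3, though each differs from it elsewhere too. A modest step toward a lower number is therefore expected, a 1.4-fold lower number from compound 3 to compound 4 (0.15 log units; within the scatter), staying close to the scatter. Compound 4 is estimated at 80000 nM, within 40000 nM to 160000 nM.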

Compound 4, half-maximal inhibitory concentration: 248000 nM
Compound 4: middle estimate off by 3.1-fold (0.49 log units), on the low side, outside the stated range (above it).
By their numbers in this assay, from the lowest: compounds 1, 2 and 3 (each within the scatter of the next, the first and the last beyond it); then compound 4.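

In this assay, going by these compounds alone, methyl in place of hydrogen on a nitrogen on an aromatic ring brings a 2.2-fold higher number from compound 3 to compound 4 (0.35 log units; beyond the scatter) and so shows this change directly, in the direction opposite to the one the earlier methyl-bearing compounds suggested. Two further single changes point the same way, with trifluoromethyl in place of hydrogen on an aromatic carbon giving a 2.6-fold higher number from compound 2 to compound 4 (0.42 log units; beyond the scatter) and amino in place of dimethylamino on a saturated chain carbon giving a 4.6-fold higher number from compound 1 to compound 4 (0.66 log units; beyond the scatter) as well. Nothing measured here explains these steps.

As far as these compounds go, whether the methyl step holds with dimethylamino on the chain remains open. So does the effect of ethyl on that nitrogen, or of chloro in place of trifluoromethyl.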